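From Ketone to Alcohol on a Shared Thienopyrimidine Scaffold

The source may hold more compounds than are shown below. What is called first, only, known or untested is meant among the compounds shown, and "the series" means these compounds.

Of the compounds shown here, two on the same core have been tested in an ADME assay on cells (Homo sapiens) for cytotoxicity, read by resazurin assay, with a stated time of 5 days; a higher number here means that more compound is tolerated, a lower number that less compound is tolerated. Compound 1, `COc1ccc(-c2nc(CNc3cccc(Cl)c3)nc3ccsc23)cn1`, gives only a limit in this assay, > 50000 nM. For the measured compounds named here, compound 2, `COc1ccc(-c2nc(CC(=O)c3cccc(Cl)c3)nc3ccsc23)cn1`, is the one compound with a number rather than a limit; in this assay compound 2 gives 30000 nM. Going by the values given here, the single measured step, an at least 1.6-fold lower number from compound 1 to compound 2 (0.22 log units; that floor lies within the scatter), sits at the edge of what repeated runs would resolve, and the limit of > 50000 nM in this assay, at which 1 of the 2 values shown sits, means the true size of that step cannot be pinned down.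

Compound 3 is `COc1ccc(-c2nc(CC(O)c3cccc(Cl)c3)nc3ccsc23)cn1`. It differs from compound 2 in one place: (3-chlorophenyl)(hydroxy)methyl in place of (3-chlorophenyl)carbonyl on a saturated chain carbon bound to an aromatic carbon. The change from compound 1 to compound 2 touched the same position, but it swapped an amino link for a carbonyl, whereas here the carbonyl becomes a hydroxy-bearing carbon; the earlier step therefore bears on this one only loosely, and its size gives no clear direction. A step in this assay of about a 1.3-fold higher number from compound 2 to compound 3 (0.12 log units; within the scatter) is expected, which is within the scatter. Compound 3 is estimated at 40000 nM, with a plausible range from 15000 nM to 100000 nM, and a real chance that the assay again reports only a limit.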

Compound 3, half-maximal cytotoxic concentration: 31000 nM
Estimate against measurement, compound 3: 1.3-fold (0.11 log units) above, and the stated range covers the measured number.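

In this assay, the exchange of (3-chlorophenyl)carbonyl for (3-chlorophenyl)(hydroxy)methyl on a saturated chain carbon bound to an aromatic carbon comes out as a 1.0-fold higher number from compound 2 to compound 3 (0.01 log units; within the scatter), so compound 2 and compound 3 cannot be told apart. This is the only pair shown at this position in which both members give a number, and it shows that a change which adds a hydrogen-bond donor and removes a double bond outside aromatic rings produces no resolved difference in tolerated concentration. The comparison with the (3-chlorophenyl)amino group reads an at least 1.6-fold lower number from compound 1 to compound 3 (0.20 log units; that floor lies within the scatter), a floor rather than a measured size, so that group cannot be separated from the other two at this position: the limit of > 50000 nM in this assay, at which 1 of the 3 values shown sits.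

The compounds shown leave open whether any group at this position can move the number beyond the scatter, and the true value of compound 1 remains unknown. As far as these compounds go, how a carboxylic acid or a longer chain at this place would read also remains open, as does whether the result holds with a methoxy group in place of the chlorine.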